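Cytotoxicity notes on a shared-core sulfone series

A few compounds are considered here, and "the series" means these few. Any claim that something is new, unique, unknown or untested is made for them only; others in the source may bear on it.

Measured so far:
compound 1 `CC(C)CCN1C(=O)C(C2=CS(=O)(=O)c3cc(NS(C)(=O)=O)ccc3N2)=C(O)[C@@H]1C(C)(C)C` — > 50000 nM
compound 2 `CC(C)(C)[C@H]1C(O)=C(C2=C(C#N)S(=O)(=O)c3cc(NS(C)(=O)=O)ccc3N2)C(=O)N1Cc1ccc(F)cc1` — > 50000 nM
compound 3 `CC(C)(C)[C@H]1C(O)=C(C2=CS(=O)(=O)c3cc(F)ccc3N2)C(=O)N1Cc1ccc(F)cc1` — > 50000 nM

In an ADME assay on 2209-23 cells (Homo sapiens) for cytotoxicity, read by WST assay and thymidine incorporation (on this read-out lower numbers stand for higher toxicity in this test and higher numbers for lower toxicity in this test), compound 1 gives > 50000 nM, which is a limit of the assay and not a number. Compound 2 gives > 50000 nM, likewise a limit. Compound 3 gives > 50000 nM, also a limit. Among the compounds with values here, compound 1 therefore stands exactly where every value shown stands, namely at the limit of > 50000 nM in this assay, at which 3 of the 3 values shown sit; no measured compound has a number that sets it apart from the others. Within the data shown here, no step between measured compounds is given, so nothing here shows how a change at the saturated chain carbon bound to the amide-type nitrogen in the ring moves this read-out.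

Compound 4 `CC(C)(C)[C@H]1C(O)=C(C2=CS(=O)(=O)c3cc(NS(C)(=O)=O)ccc3N2)C(=O)N1Cc1ccc(F)c(Cl)c1` is not yet measured. It differs from compound 1 by 3-chloro-4-fluorophenyl in place of isobutyl on a saturated chain carbon bound to an amide-type nitrogen in a ring. Given that all three measured compounds sit at the limit of > 50000 nM in this assay, at which 3 of the 3 values shown sit, compound 4 is expected to give about 60000 nM, with an expected range from 20000 nM to 200000 nM. The step that the limit leaves unreadable from compound 1 to compound 4 is expected to be none beyond the scatter, and the most likely outcome for compound 4 is again a limit rather than a number.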

Compound 4, half-maximal cytotoxic concentration: > 50000 nM
Compound 4: a limit, no number; the forecaster's own chance of this, stated with the estimate: 85%; the middle value is on the limit's open side.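

In this assay compound 4 gives > 50000 nM, a limit and not a number. Within the data shown here, compound 1 and compound 4 both sit at a limit, so no step between them can be read: the limit of > 50000 nM in this assay, at which 4 of the 4 values shown sit. The compounds shown leave open at what concentration any of them becomes toxic in this assay, and whether the change from isopentyl to 3-chloro-4-fluorobenzyl alters that concentration.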